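This account rests on a few compounds, and the source may have more. Where it says the series, first, only, none or still open, it means among the compounds named here.

In a physicochemical assay for solubility, read by HPLC, using the shake flask method, measured as kinetic solubility, with a stated time of 2 h, at pH 7.4 (a higher number here means a more soluble compound, a lower number a less soluble compound), compound 1 `Cc1cc(NCc2ccncc2)n2nc(C)c(-c3ccccc3)c2n1` gives 134000 nM. Compound 3 `Cc1cc(NCc2ccccn2)n2ncc(C3=CCOCC3)c2n1` gives 171000 nM in this assay; compound 1 holds the lower of the two numbers, yet the gap to compound 3 lies within the scatter. For compound 2 `Cc1cc(NCc2ccccn2)n2ncc(-c3cc(F)c(F)c(F)c3)c2n1` this assay returns only a limit, < 5000 nM. Among the compounds with values here, the single measured step, an at least 34-fold higher number from compound 2 to compound 3 (1.53 log units; beyond the scatter), is large, and it rests on (the limit of < 5000 nM in this assay, at which 1 of the 3 values shown sits). The change that leads to compound 4 `Cc1cc(NCC2CCCCN2)n2nc(C)c(-c3ccccc3)c2n1` sits elsewhere on the shared core: piperidin-2-yl in place of pyridin-4-yl on a saturated chain carbon bound to a nitrogen on an aromatic ring. Within the data shown here, no measured pair exchanges an aromatic ring for a saturated one at this place, so the measured step bears on it only loosely, in that it too trades an aromatic ring for a non-aromatic ring carrying one hetero atom. A smaller rise than that one is expected here. For compound 4 the estimated step is a 1.9-fold higher number from compound 1 to compound 4 (0.27 log units; within the scatter). Compound 4 is estimated at 250000 nM, with a range from 120000 nM to 600000 nM.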

Compound 4, solubility: 189000 nM
Compound 4: the middle estimate sits 1.3-fold (0.12 log units) above what was measured, within the range that was stated.
By their numbers in this assay, from the lowest: compounds 1, 3 and 4 (each within the scatter of the next). At a limit, below all of these: compound 2.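

Within the data shown here, compound 4 gives the first reading at this place on the shared core, and it shows that piperidin-2-yl can stand in place of pyridin-4-yl with no step beyond the scatter: a 1.4-fold higher number from compound 1 to compound 4 (0.15 log units; within the scatter) in this assay. The exchange of a six-membered aromatic ring for a non-aromatic one, with a hydrogen-bond donor added, therefore does not separate the two compounds in this assay, unlike the large change at the other place on the core, an at least 34-fold higher number from compound 2 to compound 3 (1.53 log units; beyond the scatter). No measurement shown accounts for this outcome.

As far as these compounds go, what a carboxylic acid or an open-chain amine would give in place of the ring at this place remains open. So does whether piperidin-2-yl would read the same on the core of compound 2.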